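Working notes: removing the methoxy from compound 2

The source may report more compounds than this note shows. Statements on the series, on what has been measured and on what is new or still open speak of the compounds shown alone.

Compound 1 `O=C(O)CCCCCCC(=O)Nc1ccc(C2=C(c3ccc(O)cc3)C3CC(S(=O)(=O)Oc4ccccc4C(F)(F)F)C2O3)cc1`: > 100000 nM
Compound 2 `COc1ccccc1OS(=O)(=O)C1CC2OC1C(c1ccc(NC(=O)CCCCCCC(=O)NO)cc1)=C2c1ccc(O)cc1`: 44700 nM

Both compounds were tested in a functional assay on DU-145 cells (Homo sapiens) for inhibition, read by MTT assay, with a stated time of 72 h; a lower number here means a stronger inhibitor, a higher number a weaker inhibitor. Compound 1 gives > 100000 nM, and this entry is a limit of the assay, not a number. Going by the values given here, compound 2 gives 44700 nM, which makes it the only compound with an actual number so far. No ranking beyond these two readings can be drawn from the data.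

Compound 3 `O=C(CCCCCCC(=O)Nc1ccc(C2=C(c3ccc(O)cc3)C3CC(S(=O)(=O)Oc4ccccc4)C2O3)cc1)NO` has not yet been measured in this assay. It differs from compound 2 in one place: hydrogen in place of methoxy on an aromatic carbon. Hydrogen stands in place of methoxy on an aromatic carbon, so 2-methoxyphenoxy becomes phenoxy. Among the compounds with values here, no measured pair shows what this change does, so the expectation starts from compound 2 at 44700 nM. No shift beyond the usual scatter is expected, and the direction is left open. The expected change is a 1.2-fold lower number from compound 2 to compound 3 (0.07 log units; within the scatter). The estimated value for compound 3 is 38000 nM, with an expected range of 14000 nM to 95000 nM.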

Compound 3, half-maximal inhibitory concentration: 37700 nM
Estimate against measurement, compound 3: 1.0-fold (0.00 log units) above, within the range that was stated.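

In this assay, replacing methoxy with hydrogen on this aromatic carbon, ortho to a large group, gives a 1.2-fold lower number from compound 2 to compound 3 (0.07 log units; within the scatter). Going by these compounds alone, this is the first pair that differs in one place, and it shows that 2-methoxyphenoxy and phenoxy cannot be told apart in this read-out, so the methoxy is not required for the level of inhibition seen with compound 2. The reading applies only to this single exchange on the shared core, and nothing shown gives a cause for it.

Going by these compounds, the effect of other groups on this aromatic carbon remains open, since a single step within the scatter says nothing about how an amine, a chlorine atom or a nitrile would read here. On these data alone, it is also open whether the same exchange would read alike on a compound with a different chain, such as a longer chain ending in the same hydroxamic acid, or whether methoxy or an amine at another carbon of the ring would move the value.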